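The compounds below may be only part of what the source reports. "The series", "measured", "known", "first", "only" and "open" are said of these compounds alone.

Three compounds have been measured in a functional assay on SK-HEP1 cells (Homo sapiens) for cytotoxicity, read by sulforhodamine B assay, with a stated time of 72 h; on this read-out higher numbers stand for weaker inhibition and lower numbers for stronger inhibition:

compound 1 `CCS(=O)(=O)Nc1cc(-c2ccc3ncnc(Nc4ccc(F)cc4)c3c2)cnc1OC` gives 1470 nM;
compound 2 `CCS(=O)(=O)Nc1cc(-c2ccc3ncnc(Nc4ccc(F)c(C(=O)OC)c4)c3c2)cnc1OC` gives 5180 nM;
compound 3 `CCS(=O)(=O)Nc1cc(-c2ccc3ncnc(Nc4ccc(C(=O)OC)c(OC)c4)c3c2)cnc1OC` gives 830 nM.

Among these three, compound 3 has the lowest number, but its gap to compound 1 is small: a 1.8-fold lower number from compound 1 to compound 3 (0.25 log units; within the scatter). Its gap to compound 2 is larger: a 6.2-fold lower number from compound 2 to compound 3 (0.80 log units; beyond the scatter). Compound 2 itself stands apart from compound 1 by a 3.5-fold higher number from compound 1 to compound 2 (0.55 log units; beyond the scatter).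

Compound 4 `CCS(=O)(=O)Nc1cc(-c2ccc3ncnc(Nc4ccc(OC)nc4)c3c2)cnc1OC` is the unmeasured compound. It differs from compound 3 in one place: 6-methoxypyridin-3-yl in place of 3-methoxy-4-(methoxycarbonyl)phenyl on a nitrogen on an aromatic ring. The group that enters is smaller than the one that leaves, so in size compound 4 lies closer to compound 1 than to compound 3.

Among the measured compounds shown here, none of the measured steps swaps in a pyridine-type ring, so no step bears on this change directly. What the three values show is that replacing one aryl group by another on this nitrogen has moved the number by small to modest amounts in both directions, with compound 1 and compound 3 close together and compound 2 the outlier. The expectation for compound 4 in this assay is therefore a number near those of compound 1 and compound 3, with the step of a 1.8-fold higher number from compound 3 to compound 4 (0.26 log units; within the scatter) estimated to fall within or just beyond the scatter. Compound 4 is estimated at 1500 nM, with a range from 500 nM to 4500 nM.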

Compound 4, half-maximal inhibitory concentration: 3440 nM
Compound 4: middle estimate off by 2.3-fold (0.36 log units), on the low side; measured number inside the range.
By their numbers in this assay, from the lowest: compounds 3 and 1 (each within the scatter of the next); then compounds 4 and 2 (each within the scatter of the next).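

In this assay, among the compounds shown here, the first pyridine-type ring at this place, 6-methoxypyridin-3-yl on a nitrogen on an aromatic ring, gives a 4.1-fold higher number from compound 3 to compound 4 (0.62 log units; beyond the scatter), so a group smaller than the one in compound 3 does not keep the number low. Nor does it match the small group of compound 1, with a 2.3-fold higher number from compound 1 to compound 4 (0.37 log units; beyond the scatter), while a 1.5-fold lower number from compound 2 to compound 4 (0.18 log units; within the scatter) puts this new group level with the group of compound 2. The four compounds now fall into two pairs, compounds 3 and 1 and compounds 4 and 2, and neither methoxycarbonyl nor fluoro sorts them, as compound 3 and compound 2 both carry the first and compound 1 and compound 2 both carry the second; nothing at hand explains this split.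

The compounds shown leave open whether the ring nitrogen or the missing methoxycarbonyl group accounts for the step from compound 3, and a 4-methoxyphenyl group on this nitrogen would separate the two. Also open, on these data alone, is how a carboxylic acid in place of the methoxycarbonyl group, or an amine in place of the methoxy group on the pyridine ring, would read here.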